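Quinone for dihydroxyphenyl: next step in a cytotoxicity series

The source may report more compounds than this note shows. Statements on the series, on what has been measured and on what is new or still open speak of the compounds shown alone.

Measured so far:
compound 1 `NS(=O)(=O)c1ccc(-n2nc(-c3ccccc3)cc2-c2cc(O)ccc2O)cc1`: 99300 nM
compound 2 `NS(=O)(=O)c1ccc(-n2nc(-c3ccc(Cl)cc3)cc2-c2cc(O)ccc2O)cc1`: 35400 nM
compound 3 `CC(=O)NS(=O)(=O)c1ccc(-n2nc(-c3ccc(Cl)cc3)cc2-c2cc(O)ccc2O)cc1`: 59800 nM

In a functional assay on cells (Cancer cell lines, Homo sapiens) for cytotoxicity, read by sulforhodamine B assay, with a stated time of 48 h (on this read-out lower numbers stand for stronger inhibition of growth and higher numbers for weaker inhibition of growth), compound 2 gives the lowest number of the three. Compound 3 sits within the scatter of it (a 1.7-fold higher number from compound 2 to compound 3 (0.23 log units; within the scatter)), while compound 1 lies beyond it (a 2.8-fold lower number from compound 1 to compound 2 (0.45 log units; beyond the scatter)). Compound 4 `NS(=O)(=O)c1ccc(-n2nc(-c3ccc(Cl)cc3)cc2C2=CC(=O)C=CC2=O)cc1` differs from compound 2 by a group of 8 heavy atoms (6 carbon, 2 oxygen; one six-membered non-aromatic ring of carbon only) in place of a group of 8 heavy atoms (6 carbon, 2 oxygen; one six-membered aromatic ring of carbon only), on an aromatic carbon. Going by the values given here, neither measured step touches this part of the molecule: one changes the chloro, the other the sulfonamide nitrogen, so no measured step bears directly on the change, and its direction in this assay cannot be read from the series. The expectation rests on compound 2 alone at 35400 nM. Compound 4 is estimated at 20000 nM with a range of 4000 nM to 100000 nM. This corresponds to an expected step of a 1.8-fold lower number from compound 2 to compound 4 (0.25 log units; within the scatter), set wide for lack of any comparable step.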

Compound 4, concentration for total growth inhibition: 50200 nM
The estimate for compound 4 lay 2.5-fold (0.40 log units) below the measured number; the range from low to high includes it.
By their numbers in this assay, from the lowest: compounds 2, 4, 3 and 1 (each within the scatter of the next, the first and the last beyond it).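

In this assay, the non-aromatic six-membered carbon ring in place of 2,5-dihydroxyphenyl gives a 1.4-fold higher number from compound 2 to compound 4 (0.15 log units; within the scatter), so this read-out does not separate the two groups at this position. The entering group has 0 hydrogen-bond donors against 2 for the leaving group, and the step still stays within the scatter. Nothing available on these compounds accounts for this result.

Open, going by these compounds, is whether an amine or a carboxylic acid at this position would give a step beyond the scatter. Also open, on these data alone, is whether this exchange gives a similar step without the chloro or with the acetyl on the sulfonamide nitrogen.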